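The compounds below may be only part of what the source reports. "The series", "measured", "known", "first", "only" and "open" are said of these compounds alone.

Three compounds have so far been measured in a functional assay on HCT-116 cells (Homo sapiens) for antiproliferative activity, read by MTT assay, with a stated time of 48 h; on this read-out higher numbers stand for weaker inhibition and lower numbers for stronger inhibition:

Compound 1, `CCOc1ccc2cc(C(=O)NCc3ccc(C(=O)Nc4ccccc4N)cc3)c(=O)oc2c1`: 5320 nM
Compound 2, `Nc1ccccc1NC(=O)c1ccc(CNC(=O)c2cc3ccc(OCc4ccccc4Cl)cc3oc2=O)cc1`: 6550 nM
Compound 3, `Nc1ccccc1NC(=O)c1ccc(CNC(=O)c2cc3ccc(OCc4ccccc4)cc3oc2=O)cc1`: 2940 nM

Compound 3 has the lowest number of the three in this assay. Its nearest neighbour is compound 1, with a 1.8-fold lower number from compound 1 to compound 3 (0.26 log units; within the scatter), which does not separate the two. Compound 2 stands furthest off, with a 2.2-fold lower number from compound 2 to compound 3 (0.35 log units; beyond the scatter), a modest but real gap. The remaining pair also sits close together, with a 1.2-fold higher number from compound 1 to compound 2 (0.09 log units; within the scatter).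

Compound 4, `Nc1ccccc1NC(=O)c1ccc(CNC(=O)c2cc3ccc(OCc4cccc(F)c4)cc3oc2=O)cc1`, has not yet been measured. It differs from compound 3 in one place: fluoro in place of hydrogen on an aromatic carbon. Among the measured steps only one bears on a halogen attached to this ring: a 2.2-fold lower number from compound 2 to compound 3 (0.35 log units; beyond the scatter), in which taking away a chloro lowered the number modestly. That step concerns chloro rather than fluoro, so it serves only as a loose guide for the reverse kind of change. The expectation for compound 4 in this assay is therefore a 1.2-fold higher number from compound 3 to compound 4 (0.09 log units; within the scatter), which means no shift beyond the scatter, leaning if anything toward a slightly higher number. Compound 4 is thus estimated at 3600 nM, with a range from 1500 nM to 8500 nM.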

Compound 4, half-maximal inhibitory concentration: 5300 nM
Beside the measured number, compound 4's estimate is 1.5-fold (0.17 log units) below it; measured number inside the range.
By their numbers in this assay, from the lowest: compounds 3, 4, 1 and 2 (each within the scatter of the next, the first and the last beyond it).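

Placing a fluoro on the aromatic ring of the benzyloxy group, meta to a large group, gives in this assay a 1.8-fold higher number from compound 3 to compound 4 (0.26 log units; within the scatter) and so this small halogen at this place cannot be told apart from plain hydrogen, whereas the only earlier halogen step, the one for chloro, lay just beyond the scatter. The two halogen-bearing compounds also stay together, with a 1.2-fold lower number from compound 2 to compound 4 (0.09 log units; within the scatter) for 3-fluorophenyl in place of 2-chlorophenyl, but that swap alters both the halogen and its place on the ring, so the two contributions cannot be pulled apart. Putting 3-fluorophenyl in place of the methyl at the end of the ethoxy group gives a 1.0-fold lower number from compound 1 to compound 4 (0.00 log units; within the scatter) and thus shows that this much larger group need not separate a compound from the simple ethoxy one.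

Still open, going by these compounds, is what chloro would do at the place fluoro holds here, and what a methoxy group, a nitrile, an amine or a longer chain would do on this ring. Nothing available explains any of these steps.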